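The compounds below may be only part of what the source reports. "The series", "measured", "known", "first", "only" and "open" are said of these compounds alone.

Measured so far: compound 1 `O=C(Nc1nnc(-c2ccc(Cl)cc2)s1)c1ccccc1` and compound 2 `O=C(Nc1nnc(-c2ccc(Cl)cc2)s1)c1c(F)cccc1F`.

In a functional assay on the whole organism (integument) for inhibition, with Chilo suppressalis as the target, read by scintillation counting, with a stated time of 72 h (on this read-out higher numbers stand for weaker inhibition and lower numbers for stronger inhibition), compound 1 gives > 5010 nM, which is a limit of the assay rather than a number. In this assay compound 2 likewise gives > 5010 nM, again a limit and not a number. Compound 2 therefore stands at the limit of > 5010 nM in this assay, at which 2 of the 2 values shown sit, so no numerical potency is known for either measured compound.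

Compound 3 `O=C(Nc1nnc(-c2ccc(Cl)cc2)s1)c1ccccc1F` differs from compound 2 by hydrogen in place of fluoro on an aromatic carbon, so it keeps the shared core of compound 2 with one fluoro fewer on the ring that bears the amide. Among the compounds with values here, since no step between measured compounds is available, and both compound 1 and compound 2 sit only at the limit, there is no basis for expecting any change beyond the usual scatter in this assay; a further limit is the most likely outcome. Compound 3 is estimated to give 9000 nM in this assay, with a range from 3000 nM to 40000 nM, an expected step that the limit leaves unreadable from compound 2 to compound 3.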

Compound 3, half-maximal inhibitory concentration: 724 nM
Compound 3: the middle estimate sits 12-fold (1.09 log units) above what was measured; the whole stated range lies above it.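

Compound 3 is the first of the series to give a number in this assay, whereas compound 1 and compound 2 each stay at a limit of the assay: the limit of > 5010 nM in this assay, at which 2 of the 3 values shown sit.

At this place, ortho to a large group, hydrogen in place of fluoro gives an at least 6.9-fold lower number from compound 2 to compound 3 (0.84 log units; beyond the scatter), while fluoro in place of hydrogen gives an at least 6.9-fold lower number from compound 1 to compound 3 (0.84 log units; beyond the scatter). Change at this aromatic carbon can therefore move the read-out beyond the scatter in either direction of substitution, and among these compounds the lower number belongs only to compound 3.

As far as these compounds go, both steps start from a limit, so their true sizes remain unknown. The compounds shown also leave open whether a chlorine, a methoxy group or an amine at this place would match the fluoro of compound 3.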